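Swapping Chloro for Piperidin-1-yl in Compound 1

This account rests on a few compounds, and the source may have more. Where it says the series, first, only, none or still open, it means among the compounds named here.

Compound 1 `Cc1cnc(Nc2ccc(Cl)cc2)nc1Nc1nc2ccccc2s1` was examined in a functional assay on MDA-MB-231 cells (Homo sapiens) for antiproliferative activity, read by MTT assay, with a stated time of 48 h (on this read-out lower numbers stand for stronger inhibition and higher numbers for weaker inhibition), and gave > 50000 nM, which is a limit of the assay and not a number. Two relatives were measured alongside it. Compound 2 `COc1ccc2nc(Nc3ccnc(Nc4ccc(S(C)(=O)=O)cc4)n3)sc2c1` gives 32700 nM in this assay. Compound 3 `COc1ccc2nc(Nc3nc(Nc4ccc(S(N)(=O)=O)cc4)ncc3C)sc2c1` returns > 50000 nM in this assay, again a limit rather than a number. Compound 1 therefore stands at the limit of > 50000 nM in this assay, at which 2 of the 3 values shown sit. Its place relative to compound 2 and compound 3 cannot be ordered from these readings.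

Compound 4 `Cc1cnc(Nc2ccc(N3CCCCC3)cc2)nc1Nc1nc2ccccc2s1` differs from compound 1 in a single place: piperidin-1-yl in place of chloro on an aromatic carbon. Within the data shown here, no two measured compounds differ in only one place, so no measured step guides what this change should do. The step from compound 1 to compound 4 is expected to be an at least 1.6-fold lower number from compound 1 to compound 4 (0.22 log units; that floor lies within the scatter), a modest gain in this assay with the number likely still weak, and a real chance that only a limit is reported again. For compound 4 an inhibitory concentration of 30000 nM is estimated, within a range from 8000 nM to 60000 nM.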

Compound 4, half-maximal inhibitory concentration: 37200 nM
Compound 4: the middle estimate sits 1.2-fold (0.09 log units) below what was measured, and the stated range covers the measured number.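

Replacing chloro with piperidin-1-yl at this position, an aromatic carbon para to a large group, gives an at least 1.3-fold lower number from compound 1 to compound 4 (0.12 log units; that floor lies within the scatter) in this assay. Among these compounds, the earlier compounds offered no step at all, so this is the first reading of what a change here does, and it yields a bound rather than a size. The full size of the step cannot be read because compound 1 carries a limit and not a number: the limit of > 50000 nM in this assay, at which 2 of the 4 values shown sit.

The compounds shown leave open whether an open-chain amine such as dimethylamino, a morpholin-4-yl ring or a carboxylic acid at this position would give a lower number than piperidin-1-yl. They also do not show whether piperidin-1-yl would have any comparable effect on relatives such as compound 2 and compound 3.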